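Benzyloxy in place of bromo: expected outcome for compound 3

The compounds below may be only part of what the source reports. "The series", "measured", "known", "first", "only" and "open" are said of these compounds alone.

Of the compounds shown here, two have been measured. Going by the values given here, compound 1 `Cc1cc(O)c(C(=O)/C=C/c2ccc(F)cc2)c(-c2ccccc2)c1C(=O)/C=C/c1ccc(F)cc1` is the first; in a functional assay on MDA-MB-231 cells (Homo sapiens) for cytotoxicity, read by MTT assay, with a stated time of 24 h (a lower number here means a stronger inhibitor, a higher number a weaker inhibitor), compound 1 gives 20000 nM. Compound 2 `Cc1cc(O)c(C(=O)/C=C/c2ccc(OCc3ccccc3)cc2)c(-c2ccc(Br)cc2)c1C(=O)/C=C/c1ccc(OCc2ccccc2)cc1` is the second; in this assay compound 2 gives 20000 nM. Compound 2 therefore stands level with compound 1 at the digits shown, compound 1 being its nearest measured neighbour, with no difference beyond the usual scatter of this assay.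

Compound 3 `Cc1cc(O)c(C(=O)/C=C/c2ccc(OCc3ccccc3)cc2)c(-c2ccc(OCc3ccccc3)cc2)c1C(=O)/C=C/c1ccc(OCc2ccccc2)cc1` has not been measured. Against compound 2 the change is benzyloxy in place of bromo on an aromatic carbon. Among the compounds with values here, no step between two measured compounds differing in a single place is available to calibrate this change; the only information is that compound 1 and compound 2, which differ from each other in several places, give the same value. On that basis the step from compound 2 to compound 3 is expected to be no larger than the scatter, in no particular direction, and is estimated as no change at the digits printed from compound 2 to compound 3 (within the scatter). Compound 3 is expected to give 20000 nM in this assay, with an estimated range from 9000 nM to 40000 nM.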

Compound 3, half-maximal inhibitory concentration: 20000 nM
Beside the measured number, compound 3's estimate shows no gap at the digits printed; measured number inside the range.
By their numbers in this assay, from the lowest: compounds 1, 2 and 3 (each within the scatter of the next).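

In this assay, benzyloxy in place of bromo on an aromatic carbon, para to a large group, gives no change at the digits printed from compound 2 to compound 3 (within the scatter). Going by these compounds alone, this is the first reading of a change made in one place, since the earlier pair differs in several places and could not be assigned to any single group. Here, a substituent of 8 heavy atoms with one six-membered aromatic ring of carbon only takes the place of a single bromine, with no step beyond the scatter in this assay, and no measurement of any property of these groups accompanies this result.

The compounds shown leave open whether a substituent of a different kind at this position, such as an amine or a carboxylic acid, would give a step beyond the scatter in this assay. They also leave open whether a single change elsewhere on the shared core, for instance at the hydroxyl group or the methyl group, would move the value, as every step read so far comes from this one position.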